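A few compounds are considered here, and "the series" means these few. Any claim that something is new, unique, unknown or untested is made for them only; others in the source may bear on it.

In a functional assay on THP-1 cells (Homo sapiens) for cytotoxicity, read by MTT assay, with a stated time of 24 h (on this read-out lower numbers stand for stronger inhibition and higher numbers for weaker inhibition), compound 1 `COc1cc(/C=C2\CN(C)C/C(=C\c3ccc(Cl)cc3)C2=O)cc(OC)c1` gives 5860 nM while compound 2 `CN1C/C(=C\c2ccc(F)cc2)C(=O)/C(=C/c2cccc([N+](=O)[O-])c2)C1` gives 7160 nM and compound 3 `CN1C/C(=C\c2ccc(Cl)cc2)C(=O)/C(=C/c2cccc([N+](=O)[O-])c2)C1` gives 7870 nM on the same read-out. All three numbers lie within the scatter of one another, so compound 3 has no separate standing among them.

The change from compound 3 to compound 4 `CN1C/C(=C\c2cccc(Br)c2)C(=O)/C(=C/c2cccc([N+](=O)[O-])c2)C1`, not yet measured, is 3-bromophenyl in place of 4-chlorophenyl on a double-bonded chain carbon bound to a double-bonded ring carbon with 3-bromophenyl in place of 4-chlorophenyl on a double-bonded chain carbon bound to a double-bonded ring carbon. Going by the values given here, one measured step bears on it: a 1.1-fold higher number from compound 2 to compound 3 (0.04 log units; within the scatter) with chloro in place of fluoro on an aromatic carbon. That step stays within the scatter. Among the compounds with values here, no measured compound carries 3-bromophenyl, so this part of the change remains untested.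

No step beyond the scatter is expected in this assay and no direction can be given with confidence. Within the data shown here, the expectation rests on compound 3 at 7870 nM and on the small size of the one measured step. The estimated move is a 1.1-fold lower number from compound 3 to compound 4 (0.05 log units; within the scatter) and it is expected to stay inside the scatter. For compound 4 the expected value is 7000 nM with an estimated range from 3500 nM to 14000 nM as the working bracket.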

Compound 4, half-maximal inhibitory concentration: 4030 nM
Estimate against measurement, compound 4: 1.7-fold (0.24 log units) above; measured number inside the range.
By their numbers in this assay, from the lowest: compounds 4, 1, 2 and 3 (each within the scatter of the next).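

In this assay, the place on a double-bonded chain carbon bound to a double-bonded ring carbon now has its first step that changes more than the halogen: 3-bromophenyl in place of 4-chlorophenyl gives a 2.0-fold lower number from compound 3 to compound 4 (0.29 log units; within the scatter) and 3-bromophenyl in place of 4-fluorophenyl gives a 1.8-fold lower number from compound 2 to compound 4 (0.25 log units; within the scatter) on the same read-out. Going by these compounds alone, both steps stay within the scatter, so with the rest of the molecule held constant, this read-out does not separate 3-bromophenyl, 4-chlorophenyl and 4-fluorophenyl at this place, though the first of these steps is far larger than the one earlier step between the two halogens. Nothing available explains these numbers.

Still open, on these data alone, is whether the bromine or its ring position contributes to these steps, a question that 4-bromophenyl and 3-chlorophenyl at the same place would separate. Also open, as far as these compounds go, is whether a group of a different kind at this place, such as an aminophenyl or a carboxyphenyl, would produce a step beyond the scatter.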